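Hydroxamic acid stilbenes: replacing the hydroxyphenyl by bromine

A few compounds are considered here, and "the series" means these few. Any claim that something is new, unique, unknown or untested is made for them only; others in the source may bear on it.

Measured so far:
compound 1 `O=C(NO)c1ccc(/C=C/c2ccnc(-c3cccc(O)c3)c2)cc1` — 19 nM
compound 2 `O=C(NO)c1ccc(/C=C/c2cccc(-c3cccc(O)c3)c2)cc1` — 200 nM

Both compounds were run in an assay on isolated protein for inhibition of protein deacetylase HDAC6 (Homo sapiens), read by fluorescence, with a stated time of 15 min; a lower number here means a stronger inhibitor, a higher number a weaker inhibitor. Compound 1 gives 19 nM and holds the lowest number of the two; the nearest is compound 2, which gives 200 nM, a gap that lies beyond the scatter, so compound 1 is the stronger of the two measured compounds. Among the compounds with values here, the two differ only in where the ring nitrogen sits in the central ring carrying the hydroxyphenyl group; no single-point step between them is counted here, and their two values speak for themselves.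

Compound 3 `O=C(NO)c1ccc(/C=C/c2ccnc(Br)c2)cc1` has not been measured in this assay. It differs from compound 1 as follows: bromo in place of 3-hydroxyphenyl on an aromatic carbon. In plain words, the 3-hydroxyphenyl group is exchanged for a bromo group. Nothing measured in the series shows the effect of removing the hydroxyphenyl group, so the expectation rests on compound 1 alone. Since compound 1 gives 19 nM, the change from compound 1 to compound 3 is expected to cost some potency, with an estimated step of a 3.2-fold higher number from compound 1 to compound 3 (0.50 log units; beyond the scatter). For compound 3 the estimate in this assay is 60 nM, with a range from 20 nM to 200 nM.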

Compound 3, half-maximal inhibitory concentration: 320 nM
Estimate against measurement, compound 3: 5.3-fold (0.73 log units) below; the whole stated range lies below it.
By their numbers in this assay, from the lowest: compound 1; then compounds 2 and 3 (each within the scatter of the next).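

In this assay the exchange of the 3-hydroxyphenyl group for a bromo group, on an aromatic carbon next to the ring nitrogen, gives a 17-fold higher number from compound 1 to compound 3 (1.23 log units; beyond the scatter) and is a large step, so a bromo group does not retain the potency of compound 1 at this position. Within the data shown here, the earlier pair changed only the place of the ring nitrogen and kept the hydroxyphenyl group, so this is the first reading of what happens when that group leaves. The step removes the carbon-only aromatic ring together with the hydrogen-bond donor and acceptor of the group, and nothing measured here separates these changes or accounts for the loss.

The compounds shown leave open how much of the step belongs to the hydroxyl group and how much to the carbon ring, a question that a plain phenyl or a 3-methoxyphenyl group at this position would address. They also leave open whether a bromo group costs as much on the core of compound 2, whose central ring lacks the ring nitrogen.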